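The compounds below may be only part of what the source reports. "The series", "measured", "known", "first", "only" and "open" are said of these compounds alone.

In a functional assay on LNCaP cells (Homo sapiens) for inhibition, read by MTT assay (on this read-out higher numbers stand for weaker inhibition of growth and lower numbers for stronger inhibition of growth), compound 1 `CC1=C(/C=C/C(C)=C/C=C/C(C)=C\C(=O)Nc2ccc(O)cc2)C(C)(C)CCC1n1ccnc1` gives 3540 nM, compound 2 `CC1=C(/C=C/C(C)=C/C=C/C(C)=C\C(=O)Nc2cccc(F)c2)C(C)(C)CCC1n1ccnc1` gives 2690 nM and compound 3 `CC1=C(/C=C/C(C)=C/C=C/C(C)=C\C(=O)Nc2ccc(F)cc2)C(C)(C)CCC1n1ccnc1` gives 3890 nM. Compound 3 therefore stands level with the other two, within the scatter. Compound 4 `CC1=C(/C=C/C(C)=C/C=C/C(C)=C\C(=O)NCc2ccccc2)C(C)(C)CCC1n1ccnc1` differs from it by benzyl in place of 4-fluorophenyl on an amide-type nitrogen, with benzyl in place of 4-fluorophenyl on an amide-type nitrogen. The measured steps that bear on this change are small: a 1.1-fold higher number from compound 1 to compound 3 (0.04 log units; within the scatter), a 1.4-fold higher number from compound 2 to compound 3 (0.16 log units; within the scatter) and a 1.3-fold lower number from compound 1 to compound 2 (0.12 log units; within the scatter). None of them tests a benzyl group, so direct evidence is missing. In this assay, no step beyond the scatter is expected, and no direction is favoured. The expected change is a 1.1-fold lower number from compound 3 to compound 4 (0.06 log units; within the scatter). For compound 4, the estimate is 3400 nM, with an expected range from 1500 nM to 7500 nM.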

Compound 4, concentration for 50% growth inhibition: > 100000 nM
Compound 4: a limit, no number (the forecaster's own chance of this, stated with the estimate: 3%); middle value at least 29-fold (1.46 log units) away from the limit.
By their numbers in this assay, from the lowest: compounds 2, 1 and 3 (each within the scatter of the next). At a limit, above all of these: compound 4.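

Compound 4 gives no number in this assay, only a limit of the assay: the limit of > 100000 nM in this assay, at which 1 of the 4 values shown sits. The earlier changes among 4-hydroxyphenyl, 3-fluorophenyl and 4-fluorophenyl on the amide-type nitrogen all stayed within the scatter, but benzyl there brings large steps: an at least 25-fold higher number from compound 3 to compound 4 (1.41 log units; beyond the scatter), an at least 37-fold higher number from compound 2 to compound 4 (1.57 log units; beyond the scatter) and an at least 28-fold higher number from compound 1 to compound 4 (1.45 log units; beyond the scatter). This place on the molecule is therefore not indifferent to every group of this size.

The compounds shown leave open whether a methyl group, a phenethyl chain or a pyridyl ring on that nitrogen would fall with the phenyl groups or with benzyl.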